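The compounds below may be only part of what the source reports. "The series", "measured", "known", "first", "only" and "open" are said of these compounds alone.

Measured in a functional assay on DLD-1 cells (Homo sapiens) for cytotoxicity, read by WST assay, with a stated time of 72 h; on this read-out higher numbers stand for weaker inhibition and lower numbers for stronger inhibition:
compound 1 `COc1cc2c(Nc3nc4ccc(C(=O)Nc5c(C)cccc5Cl)cc4s3)ncnc2cc1OCCCN1CCC(C)CC1`: 11300 nM
compound 2 `CCN(CC)CCCOc1cc2ncnc(Nc3nc4ccc(C(=O)Nc5c(C)cccc5Cl)cc4s3)c2cc1OC`: 11700 nM
compound 3 `COc1cc2c(Nc3nc4ccc(C(=O)Nc5c(C)cc(C)cc5C)cc4s3)ncnc2cc1OCCCN1CCCC1`: 5900 nM

Compound 3 gives the lowest of the three numbers, but its gaps to compound 1 and to compound 2 both fall within the scatter, so no order among the three is secure. Compound 4 `COc1cc2c(Nc3nc4ccc(C(=O)Nc5c(C)cccc5Cl)cc4s3)ncnc2cc1OCCCN1CCCC1` differs from compound 3 in one place: 2-chloro-6-methylphenyl in place of 2,4,6-trimethylphenyl on an amide-type nitrogen. For the measured compounds named here, no measured step covers this exchange on the amide-type nitrogen; the one measured step, a 1.0-fold higher number from compound 1 to compound 2 (0.02 log units; within the scatter), concerns the amine end of the chain and lies within the scatter. Compounds 1 and 2 carry the same 2-chloro-6-methylphenyl as compound 4, and their numbers lie within the scatter of compound 3, though that comparison also changes the chain amine. Compound 4 is therefore expected close to the measured compounds, with a step of a 1.6-fold higher number from compound 3 to compound 4 (0.21 log units; within the scatter) not expected to exceed the scatter. The estimate for compound 4 in this assay is 9500 nM, between 4000 nM and 24000 nM.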

Compound 4, half-maximal inhibitory concentration: 60700 nM
Compound 4: middle estimate off by 6.4-fold (0.81 log units), on the low side; the whole stated range lies below it.
By their numbers in this assay, from the lowest: compounds 3, 1 and 2 (each within the scatter of the next); then compound 4.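

On the amide-type nitrogen, 2-chloro-6-methylphenyl in place of 2,4,6-trimethylphenyl is far from a neutral exchange: this assay gives a 10-fold higher number from compound 3 to compound 4 (1.01 log units; beyond the scatter) for this change. With 2-chloro-6-methylphenyl held fixed, the chain amine also counts, with pyrrolidin-1-yl giving a 5.2-fold higher number from compound 2 to compound 4 (0.72 log units; beyond the scatter) and a 5.4-fold higher number from compound 1 to compound 4 (0.73 log units; beyond the scatter) here, although diethylamino and 4-methylpiperidin-1-yl remain within the scatter of each other. No measured evidence accounts for these steps.

Open, from the compounds shown here alone, is whether the aryl step holds with diethylamino or 4-methylpiperidin-1-yl on the chain. Also open, going by these compounds, is how 2,6-dimethylphenyl would read on the amide-type nitrogen, which would separate the chlorine from the third methyl.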